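A few compounds are considered here, and "the series" means these few. Any claim that something is new, unique, unknown or untested is made for them only; others in the source may bear on it.

Measured compounds in an assay on isolated protein for inhibition of long-chain fatty acid transport protein 1 (Mus musculus), read by scintillation counting, with a stated time of 20 min; a lower number here means a stronger inhibitor, a higher number a weaker inhibitor:
Compound 1 `Cc1ccc(N2CCN(CC(=O)Nc3nc4c(s3)CCCC4)CC2)cc1` — > 10000 nM, a limit of the assay
Compound 2 `O=C(CN1CCN(c2ccc(F)cc2)CC1)Nc1nc2c(o1)CCCC2` — 5400 nM
Compound 3 `O=C(CN1CCN(c2ccc(F)cc2)CC1)Nc1nc2c(s1)CCC2` — > 10000 nM, a limit of the assay

Compound 1 stands at the weak end of what has been recorded: in this assay compound 1 gives only a limit, > 10000 nM, and no number. The same holds for compound 3, whose result in this assay, > 10000 nM, is likewise a limit. Only compound 2 yields a number in this assay, 5400 nM, and it is a weak one. The evidence is the limit of > 10000 nM in this assay, at which 2 of the 3 values shown sit.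

Compound 4 `O=C(CN1CCN(C2CCCCC2)CC1)Nc1nc2c(s1)CCCC2` has not yet been measured. It differs from compound 1 in one place: cyclohexyl in place of 4-methylphenyl on an amine nitrogen in a ring. Among the compounds with values here, no step between two measured compounds is available to calibrate this change, so its size is a matter of expectation. The writer expects no step beyond the scatter of this assay, with compound 4 likely remaining near or beyond the limit, so that the step of an at least 1.1-fold lower number from compound 1 to compound 4 (0.04 log units; that floor lies within the scatter) is estimated as small. Compound 4 is expected to give about 9000 nM in this assay, within a range from 3000 nM to 30000 nM.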

Compound 4, half-maximal inhibitory concentration: > 10000 nM
Compound 4 was reported as a limit; the forecaster's own chance of this, stated with the estimate: 55%; middle value at least 1.1-fold (0.04 log units) from the limit.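

In this assay compound 4 gives > 10000 nM, a limit of the assay and not a number. Compound 1 also gives only a limit, so no step can be read from compound 1 to compound 4. The compounds shown leave open whether cyclohexyl or 4-methylphenyl gives the lower number.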